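Three Aryl Groups Measured, a Fourth Still Unknown

A few compounds are considered here, and "the series" means these few. Any claim that something is new, unique, unknown or untested is made for them only; others in the source may bear on it.

Measured in a functional assay on CHO cells for agonist activity at Free fatty acid receptor 1 (Homo sapiens), read by FLIPR and calcium flux, tested at 100 nM; on this read-out higher numbers stand for a stronger effect at the one concentration tested and lower numbers for a weaker effect:
compound 1, `Cc1nc(-c2ccccc2Cl)sc1COc1ccc2c(c1)OCC2CC(=O)O`, gives 12.4%
compound 2, `Cc1nc(-c2ccc(F)cc2)sc1COc1ccc2c(c1)OCC2CC(=O)O`, gives 61.6%
compound 3, `Cc1nc(-c2cccc(C(F)(F)F)c2)sc1COc1ccc2c(c1)OCC2CC(=O)O`, gives 35.7%

Compound 3 stands second of the three numbers in this assay. The steps that place it are a number 23.3 percentage points higher from compound 1 to compound 3 (beyond the scatter) and a number 25.9 percentage points lower from compound 2 to compound 3 (beyond the scatter); the remaining step is a number 49.2 percentage points higher from compound 1 to compound 2 (beyond the scatter). All three steps exchange one aryl group for another on the same carbon of the shared core.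

Compound 4, `COc1cc(OC)cc(-c2nc(C)c(COc3ccc4c(c3)OCC4CC(=O)O)s2)c1`, has not been measured. It differs from compound 3 in one place:
3,5-dimethoxyphenyl in place of 3-(trifluoromethyl)phenyl on an aromatic carbon

For the measured compounds named here, no measured step brings in 3,5-dimethoxyphenyl, so none bears directly on this change. The measured aryl exchanges moved this assay by modest to large amounts in both directions, which gives the size of step to expect but not its sign. Compound 4 is therefore expected near the middle of the measured range, a number 0.7 percentage points lower from compound 3 to compound 4 (within the scatter), with wide uncertainty. The estimate for compound 4 is 35%, between 10% and 65%.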

Compound 4, a percentage reported as activity, at one concentration (the size of the read-out at that concentration, not a potency): 17.5%
Compound 4: middle estimate off by 17.5 percentage points, on the high side, and the stated range covers the measured number.
By their numbers in this assay, from the lowest: compounds 1 and 4 (each within the scatter of the next); then compound 3; then compound 2.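

In this assay, placing 3,5-dimethoxyphenyl on this aromatic carbon of the five-membered ring gives a number 18.2 percentage points lower from compound 3 to compound 4 (beyond the scatter) and a number 44.1 percentage points lower from compound 2 to compound 4 (beyond the scatter). The same change gives a number 5.1 percentage points higher from compound 1 to compound 4 (within the scatter), so two differently substituted aryl groups now share the low end of the measured numbers. Nothing shown explains why these aryl groups differ. Going by these compounds, it remains open whether one methoxy group on the phenyl ring would give a number nearer that of compound 3 or compound 4, and how an unsubstituted phenyl or an amine-bearing phenyl would read.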